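This account rests on a few compounds, and the source may have more. Where it says the series, first, only, none or still open, it means among the compounds named here.

Working notes on the amide series

Three amides sharing one core have numbers in a functional assay on the whole organism (strain Swiss Albino) for inhibition, with Mus musculus as the target, in the writhing test, with a stated time of 1 h, at a dose of 100 mg/kg by the oral route; a lower number here means less inhibition, a higher number more inhibition at the dose given (going by the name of the read-out). Compound 1 `COc1cc2c(cc1OC)C(CC(=O)Nc1ccccc1)CC2` gives 42.8% there, the second highest of the three. Compound 2 `COc1cc2c(cc1OC)C(CC(=O)Nc1cccc(C)c1)CC2` gives 54.3%, the step being a number 11.5 percentage points higher from compound 1 to compound 2 (beyond the scatter). Compound 3 `COc1ccccc1NC(=O)CC1CCc2cc(OC)c(OC)cc21` gives 24.5%, the step being a number 18.3 percentage points lower from compound 1 to compound 3 (beyond the scatter); from compound 2 the step is a number 29.8 percentage points lower from compound 2 to compound 3 (beyond the scatter).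

Compound 4 `COc1cc2c(cc1OC)C(CC(=O)Nc1cccnc1)CC2` is not yet measured in this assay. Its difference from compound 1 is pyridin-3-yl in place of phenyl on an amide-type nitrogen. None of the three measured steps swaps the aromatic ring itself; the two that alter the ring on the amide-type nitrogen go in opposite directions, one upward by a modest amount and one downward by a modest amount. The data give no direct guide for a ring carrying a nitrogen, so the expected step of a number 2.8 percentage points lower from compound 1 to compound 4 (within the scatter) is small and could fall either way, most likely within the scatter. Compound 4 is therefore estimated at 40%, with a range from 24% to 56%.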

Compound 4, a percentage reported as inhibition, in the whole organism at one dose (the size of the read-out at that dose, not a potency): 70.7%
Compound 4: the middle estimate sits 30.7 percentage points below what was measured; measured number above the stated range.
By their numbers in this assay, from the lowest: compound 3; then compound 1; then compound 2; then compound 4.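

In this assay, replacing the ring on the amide-type nitrogen, rather than adding a group to phenyl, gives a number 27.9 percentage points higher from compound 1 to compound 4 (beyond the scatter), and this is the only step shown that brings a nitrogen into that ring. Compound 4 stands highest of the four, with a number 16.4 percentage points higher from compound 2 to compound 4 (beyond the scatter) and a number 46.2 percentage points higher from compound 3 to compound 4 (beyond the scatter), so at this dose pyridin-3-yl exceeds not only phenyl but also the 3-methylphenyl ring, the best of the carbon-only rings shown. No available evidence bears on why the number rises with this change.

The compounds shown leave open how pyridin-2-yl or pyridin-4-yl would compare with pyridin-3-yl on the same amide-type nitrogen. They also leave open whether a methyl or methoxy group on the pyridin-3-yl ring would shift the number in the same direction as on phenyl.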